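Weak Cytotoxicity of Diaminoquinoxaline Analogues on Colon Cells

The source may hold more compounds than are shown below. What is called first, only, known or untested is meant among the compounds shown, and "the series" means these compounds.

Measured compounds:
- compound 1, `Nc1cc(N)c2nc(-c3ccccc3)c(Oc3ccc(F)cc3)nc2c1`: < 100000 nM in a functional assay on KM12 cells (Homo sapiens) for inhibition, read by sulforhodamine B assay, with a stated time of 48 h; a higher number here means that more compound is tolerated, a lower number that less compound is tolerated
- compound 2, `COc1ccc(CNc2nc3cc(N)cc(N)c3nc2-c2ccccc2)cc1OC`: 72400 nM in this assay

Compound 1 reaches only a limit of this assay, < 100000 nM, so it gives no number. Within the data shown here, compound 2 is therefore the only compound with a number here, and that number, 72400 nM, is high, meaning that a great deal of compound is tolerated by the cells over the stated time. The one limit, (the limit of < 100000 nM in this assay, at which 1 of the 2 values shown sits), does not contradict this picture, but it adds no number to compare with.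

Compound 3, `Nc1cc(N)c2nc(-c3ccccc3)c(NCc3ccc(F)cc3)nc2c1`, has not yet been measured in this assay. It keeps the shared core of compound 2 and the amine-linked benzyl arm, and differs by one replacement: 4-fluorophenyl in place of 3,4-dimethoxyphenyl on a saturated chain carbon bound to a nitrogen on an aromatic ring. Among the measured compounds shown here, no step between two measured compounds exists to guide this change.

Without such a step, compound 3 is expected to sit close to compound 2, with any movement falling within the usual scatter; the estimated step of a 1.1-fold higher number from compound 2 to compound 3 (0.04 log units; within the scatter) is therefore small. Compound 3 is estimated at 80000 nM, within a range from 30000 nM to 150000 nM.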

Compound 3, concentration lethal to 50% of the cells: < 100000 nM
Compound 3: a limit, no number; the forecaster's own chance of this, stated with the estimate: 40%; the middle value lies beyond the limit too.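

In this assay compound 3 gives < 100000 nM, which is a limit and not a number. No step to compound 3 can be read, from compound 1 or from compound 2, because a limit gives no size: the limit of < 100000 nM in this assay, at which 2 of the 3 values shown sit.

The compounds shown leave open whether 4-fluorophenyl in place of 3,4-dimethoxyphenyl moves the read-out at all.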